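The source may hold more compounds than are shown below. What is called first, only, known or untested is meant among the compounds shown, and "the series" means these compounds.

Compound 1 `O=C1C(N2CCCCC2)=NN(c2ccc(Cl)cc2)CN1c1ccccc1Cl` gives in a functional assay on K562 cells (Homo sapiens) for antiproliferative activity, read by resazurin assay, with a stated time of 72 h (on this read-out lower numbers stand for stronger inhibition of growth and higher numbers for weaker inhibition of growth), only the assay limit of > 50 ug/mL. Compound 2 `O=C1C(N2CCCCC2)=NN(c2ccccc2)CN1c1ccccc1Cl` gives 42 ug/mL in this assay. For the measured compounds named here, the one measured step, an at least 1.1-fold lower number from compound 1 to compound 2 (0.07 log units; that floor lies within the scatter), touches a different part of the molecule and rests on the limit (the limit of > 50 ug/mL in this assay, at which 1 of the 2 values shown sits), so it does not inform the change to compound 3 `O=C1C(N2CCCC2)=NN(c2ccc(Cl)cc2)CN1c1ccccc1Cl`, which differs from compound 1 as follows: pyrrolidin-1-yl in place of piperidin-1-yl on a carbon with a double bond to nitrogen. Going by the values given here, no measured step probes this change, so no shift beyond the scatter is expected in this assay. Compound 3 is therefore estimated at 60 ug/mL, within 25 ug/mL to 150 ug/mL, corresponding to a step that the limit leaves unreadable from compound 1 to compound 3.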

Compound 3, concentration for 50% growth inhibition: 8.6 ug/mL
Compound 3: middle estimate off by 7.0-fold (0.84 log units), on the high side; measured number below the stated range.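

At the carbon with a double bond to nitrogen, the swap from the six-membered piperidin-1-yl to the five-membered pyrrolidin-1-yl gives an at least 5.8-fold lower number from compound 1 to compound 3 (0.76 log units; beyond the scatter) in this assay. This shows that the position responds to this change, which the earlier step, made elsewhere in the molecule, could not show. The true size of the step remains a floor because compound 1 gives only a limit: the limit of > 50 ug/mL in this assay, at which 1 of the 3 values shown sits.

The compounds shown leave open how morpholin-4-yl, azetidin-1-yl or an open-chain dimethylamino group would read at this position. They also leave open whether pyrrolidin-1-yl has the same effect with phenyl in place of the 4-chlorophenyl group.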